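Adding a Methylsulfonyl Group to Compound 2

The source may hold more compounds than are shown below. What is called first, only, known or untested is meant among the compounds shown, and "the series" means these compounds.

Of the compounds shown here, three sharing one core have been measured in an assay on V79 cells for inhibition of cytochrome P450 11B1, mitochondrial (Homo sapiens), read by HTRF, with a stated time of 1 h; a lower number here means a stronger inhibitor, a higher number a weaker inhibitor. Compound 1 `FC(F)(F)c1ccc2c(c1)nc(-c1cccnc1)n2C1CC1` carries a trifluoromethyl group; in this assay compound 1 gives > 10000 nM, which is a limit of the assay and not a number. Compound 2 `c1cncc(-c2nc3ccccc3n2C2CC2)c1` has hydrogen in that place; compound 2 gives > 8330 nM, again only a limit. Compound 3 `Fc1cccc2c1nc(-c1cccnc1)n2C1CC1` bears a fluoro group; compound 3 gives > 8330 nM, also a limit. Compound 2 therefore stands at a limit, and the two further values are limits as well. The first step, hydrogen in place of trifluoromethyl on an aromatic carbon, is a step that the two limits leave unreadable from compound 1 to compound 2; the second step, fluoro in place of hydrogen on an aromatic carbon, is a step that the two limits leave unreadable from compound 2 to compound 3. Both rest on the limit of > 10000 nM in this assay, at which 1 of the 3 values shown sits, and (the limit of > 8330 nM in this assay, at which 2 of the 3 values shown sit), so neither tells how a substituent on this ring shifts the number.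

Compound 4 `CS(=O)(=O)c1ccc2c(c1)nc(-c1cccnc1)n2C1CC1` differs from compound 2 by methylsulfonyl in place of hydrogen on an aromatic carbon. Within the data shown here, no measured step has a readable size, so no direction beyond the scatter can be expected. Compound 4 is expected to remain near the limits seen for its relatives, with an estimated step that the limit leaves unreadable from compound 2 to compound 4. The estimate for compound 4 is 10000 nM, ranging from 2000 nM to 50000 nM.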

Compound 4, half-maximal inhibitory concentration: > 10000 nM
Compound 4 was reported as a limit; the forecaster's own chance of this, stated with the estimate: 70%; the middle value sits exactly at the limit.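

In this assay compound 4 gives > 10000 nM, which is a limit of the assay and not a number. No step from compound 2 or compound 1 to compound 4 can be read, because all three values are limits: the limit of > 10000 nM in this assay, at which 2 of the 4 values shown sit. The same holds for the second limit: the limit of > 8330 nM in this assay, at which 2 of the 4 values shown sit.

The compounds shown leave open whether any substituent on this ring gives a readable number in this assay.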